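Benzyl ether changes in the series: compound 2 to compound 3

The source may hold more compounds than are shown below. What is called first, only, known or untested is meant among the compounds shown, and "the series" means these compounds.

- compound 1 `COc1cc(OC)c(-c2coc3cc(OCc4ccccc4C(F)(F)F)ccc3c2=O)cc1OC`: 4760 nM
- compound 2 `COc1cc(OC)c(-c2coc3cc(OCc4ccc(C#N)cc4)ccc3c2=O)cc1OC`: 4220 nM

Among the compounds with values here, in a functional assay on HCT-116 cells (Homo sapiens) for antiproliferative activity, read by MTT assay, with a stated time of 24 h (on this read-out lower numbers stand for stronger inhibition and higher numbers for weaker inhibition), compound 2 stands within the scatter of compound 1, the only other measured number. Compound 3 `COc1cc(OC)c(-c2coc3cc(OCc4cccc(F)c4)ccc3c2=O)cc1OC` follows from compound 2 by 3-fluorophenyl in place of 4-cyanophenyl on a saturated chain carbon bound to an oxygen on an aromatic ring. This places 3-fluorophenyl where 4-cyanophenyl stood, on a saturated chain carbon bound to an oxygen on an aromatic ring. Within the data shown here, the single measured step bearing on this place, a 1.1-fold lower number from compound 1 to compound 2 (0.05 log units; within the scatter), is small. No change beyond the scatter is therefore expected, and the estimated step is a 1.0-fold higher number from compound 2 to compound 3 (0.01 log units; within the scatter). Compound 3 is expected at 4300 nM, with an estimated range of 2100 nM to 8500 nM.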

Compound 3, half-maximal inhibitory concentration: 4920 nM
For compound 3 the middle estimate is 1.1-fold (0.06 log units) below the measured one; the measured number falls inside the stated range.
By their numbers in this assay, from the lowest: compounds 2, 1 and 3 (each within the scatter of the next).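

In this assay, a 1.2-fold higher number from compound 2 to compound 3 (0.07 log units; within the scatter) and a 1.0-fold higher number from compound 1 to compound 3 (0.01 log units; within the scatter) leave 2-(trifluoromethyl)phenyl, 4-cyanophenyl and 3-fluorophenyl on the saturated chain carbon bound to an oxygen on an aromatic ring within the scatter of one another. With a third substituted phenyl, the exchange still does not separate the compounds at this place. Nothing at hand offers an explanation for this flat result. Still open, on these data alone, is whether a piperidine amine, a carboxylic acid or a longer chain in place of these phenyl groups would give a step beyond the scatter.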